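This account rests on a few compounds, and the source may have more. Where it says the series, first, only, none or still open, it means among the compounds named here.

Compound 1 `ClCc1ccc(Cn2cnc3c(Cl)ncnc32)cc1`: "not determined" (no result reported)
Compound 2 `ClCc1ccccc1Cn1cnc2c(Cl)nc(Cl)nc21`: > 100000 nM

Two compounds carry entries, but only one of them a result. Compound 1 `ClCc1ccc(Cn2cnc3c(Cl)ncnc32)cc1` was not taken through the assay, so its entry reads "not determined" (no result reported). Compound 2 `ClCc1ccccc1Cn1cnc2c(Cl)nc(Cl)nc21` was tested in a functional assay on HT-29 cells (Homo sapiens) for cytotoxicity, read by sulforhodamine B assay, with a stated time of 48 h; a lower number here means that less compound is tolerated, a higher number that more compound is tolerated. In this assay compound 2 reaches only > 100000 nM, which is a limit of the assay and not a number. Going by the values given here, compound 2 thus stands at the limit of > 100000 nM in this assay, at which 1 of the 2 values shown sits, and with the other entry holding no single number there is no measured step anywhere in the set.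

Compound 3 `ClCc1ccccc1Cn1cnc2c(Cl)ncnc21` differs from compound 2 by hydrogen in place of chloro on an aromatic carbon. Among the compounds with values here, no measured step guides the size of this change. Since compound 2 sits at a limit, as the limit of > 100000 nM in this assay, at which 1 of the 2 values shown sits, records, the step from compound 2 to compound 3 is expected to be a number no higher from compound 2 to compound 3 (the limit leaves the size open), nothing beyond the scatter in either direction. Compound 3 is therefore estimated at 100000 nM in this assay, within a range from 30000 nM to 300000 nM, and the assay is expected most likely to report only a limit again.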

Compound 3, concentration lethal to 50% of the cells: > 100000 nM
Compound 3 was reported as a limit (the forecaster's own chance of this, stated with the estimate: 70%); the middle value lies on the limit itself.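

Compound 2 and compound 3 are both reported in this assay only as limits and not as numbers, and the step between them cannot be read. The compounds shown leave open whether hydrogen in place of chloro on an aromatic carbon changes the concentration tolerated, and where either compound would fall as a single number.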